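From 4-chlorophenyl to cyclohexyl on the ring nitrogen

The source may hold more compounds than are shown below. What is called first, only, known or untested is meant among the compounds shown, and "the series" means these compounds.

Measured so far in a functional assay on MCF7 cells (Homo sapiens) for antiproliferative activity, read by MTT assay, with a stated time of 72 h; on this read-out higher numbers stand for weaker inhibition and lower numbers for stronger inhibition:
- compound 1 `O=C1COc2ccc(-c3cccc(NS(=O)(=O)c4ccc(F)cc4)c3)cc2N1` gives 18300 nM
- compound 2 `O=C1COc2ccc(-c3cccc(NS(=O)(=O)c4ccc(F)cc4)c3)cc2N1c1ccc(Cl)cc1` gives 39800 nM
- compound 3 `COc1ncc(-c2ccc3c(c2)N(c2ccc(Cl)cc2)C(=O)CO3)cc1NS(=O)(=O)c1ccc(F)cc1` gives 27600 nM

Compound 2 and compound 3 lie within the scatter of each other, while compound 2 stands beyond the scatter from compound 1, with the higher number. Compound 4 `O=C1COc2ccc(-c3cccc(NS(=O)(=O)c4ccc(F)cc4)c3)cc2N1C1CCCCC1` keeps the core of compound 2 but has cyclohexyl in place of 4-chlorophenyl on an amide-type nitrogen in a ring. Among the compounds with values here, one measured step bears on this place, a modest one that puts 4-chlorophenyl in place of hydrogen: a 2.2-fold higher number from compound 1 to compound 2 (0.34 log units; beyond the scatter). Within the data shown here, no measured step exchanges one ring for another on that nitrogen, so the evidence is thin. In this assay a change smaller than that modest step is expected, with no clear direction and nothing beyond the scatter. The expected change is a 1.2-fold lower number from compound 2 to compound 4 (0.09 log units; within the scatter). For compound 4 the estimated value is 32000 nM, with an expected range from 14000 nM to 70000 nM.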

Compound 4, half-maximal inhibitory concentration: 21400 nM
Beside the measured number, compound 4's estimate is 1.5-fold (0.17 log units) above it, and the stated range covers the measured number.
By their numbers in this assay, from the lowest: compounds 1, 4, 3 and 2 (each within the scatter of the next, the first and the last beyond it).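

At this ring nitrogen in this assay, replacing 4-chlorophenyl with cyclohexyl gives a 1.9-fold lower number from compound 2 to compound 4 (0.27 log units; within the scatter) and replacing hydrogen with cyclohexyl gives a 1.2-fold higher number from compound 1 to compound 4 (0.07 log units; within the scatter) so compound 4 cannot be separated from either neighbour. The earlier compounds showed only that 4-chlorophenyl on this nitrogen gave a step beyond the scatter, whereas the non-aromatic carbon ring does not stand apart from hydrogen or from the aromatic ring, and the aromatic ring is therefore not shown to be required at this position. Nothing available explains either step.

The compounds shown leave open whether a methyl group, a longer chain, or a chain ending in an amine or a carboxylic acid on this nitrogen would move the number beyond the scatter. They also leave open whether cyclohexyl would behave the same way on the core of compound 3.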